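This account rests on a few compounds, and the source may have more. Where it says the series, first, only, none or still open, it means among the compounds named here.

Measured so far:
compound 1, `COc1ccc(-n2c(=O)n(Cc3cc4cc(Cl)ccc4n3CCCC#N)c3cnccc32)c(F)c1` — > 50000 nM
compound 2, `O=c1n(Cc2nc3ncccc3n2CCCCO)c2cnccc2n1C1CC1` — > 100000 nM

In an ADME assay on HeLa cells (Homo sapiens) for cytotoxicity, read by ATP content, with a stated time of 3 days (a higher number here means that more compound is tolerated, a lower number that less compound is tolerated), compound 1 gives > 50000 nM, which is a limit of the assay rather than a number. Compound 2 gives > 100000 nM, likewise a limit. Compound 1 stands at a limit, and the other value shown is a limit too (the limit of > 100000 nM in this assay, at which 1 of the 2 values shown sits, (the limit of > 50000 nM in this assay, at which 1 of the 2 values shown sits)), so no order between the two compounds can be read from these numbers. Among the compounds with values here, no step between measured compounds is available.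

Compound 3, `N#CCCCn1c(Cn2c(=O)n(-c3ncccn3)c3ccncc32)cc2cc(Cl)ccc21`, is to be measured in this assay. It differs from compound 1 by pyrimidin-2-yl in place of 2-fluoro-4-methoxyphenyl on an aromatic nitrogen. Within the data shown here, with no measured step to rest on, no step beyond the scatter is expected in either direction. The expected value for compound 3 is 60000 nM, with a range from 20000 nM to 200000 nM, most likely again reported only as a limit. The expected step that the limit leaves unreadable from compound 1 to compound 3 is accordingly small.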

Compound 3, half-maximal cytotoxic concentration: > 50000 nM
Compound 3 ended at the assay's limit; the forecaster's own chance of this, stated with the estimate: 85%; the middle value lies beyond the limit too.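

In this assay, no step can be read from compound 1 to compound 3, and both values are limits: the limit of > 50000 nM in this assay, at which 2 of the 3 values shown sit.

The compounds shown leave open how far pyrimidin-2-yl in place of 2-fluoro-4-methoxyphenyl on an aromatic nitrogen shifts the half-maximal cytotoxic concentration, if at all.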